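This account rests on a few compounds, and the source may have more. Where it says the series, first, only, none or still open, it means among the compounds named here.

Measured compounds: compound 1 `O=C1/C(=C/c2ccccc2)CCc2ccc(O)cc21` gives 710 nM in a functional assay on RAW264.7 cells (Mus musculus) for inhibition; a higher number here means a weaker inhibitor, a lower number a stronger inhibitor; compound 2 `O=C1/C(=C/c2ccccc2Cl)CCc2ccc(O)cc21` gives 270 nM in this assay.

Going by the values given here, compound 1 holds the higher of the two numbers; the only measured step is a 2.6-fold lower number from compound 1 to compound 2 (0.42 log units; beyond the scatter), a chloro in place of hydrogen on an aromatic carbon. Compound 3 `O=C1/C(=C/c2cccc(O)c2)CCc2ccc(O)cc21` differs from compound 1 by hydroxy in place of hydrogen on an aromatic carbon, meta to a large group. The step from compound 1 to compound 2 bears on this only loosely, as it concerns a different group at a different place. A small downward step, possibly within the scatter, is therefore expected, a 1.3-fold lower number from compound 1 to compound 3 (0.11 log units; within the scatter). Compound 3 is estimated at 550 nM, within 220 nM to 1400 nM.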

Compound 3, half-maximal inhibitory concentration: 810 nM
Beside the measured number, compound 3's estimate is 1.5-fold (0.17 log units) below it, within the range that was stated.
By their numbers in this assay, from the lowest: compound 2; then compounds 1 and 3 (each within the scatter of the next).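

In this assay, hydroxy in place of hydrogen on an aromatic carbon, meta to a large group, gives a 1.1-fold higher number from compound 1 to compound 3 (0.06 log units; within the scatter) and so leaves the number where it was. At this position, then, adding this one group does not separate compound 3 from compound 1, whereas the chloro change at its different place gave a 2.6-fold lower number from compound 1 to compound 2 (0.42 log units; beyond the scatter). No measured evidence accounts for this result.

The compounds shown leave open whether a methoxy group or an amine at this same position would shift the number. They also leave open how hydroxy would behave elsewhere on this ring.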